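From fluoro to methyl in an antiproliferative series

A few compounds are considered here, and "the series" means these few. Any claim that something is new, unique, unknown or untested is made for them only; others in the source may bear on it.

Compound 1 `COc1c(OC(C)C)cc2occ(-c3csc4ccccc34)c(=O)c2c1O`: > 10000 nM
Compound 2 `COc1c(OC(C)C)cc2ccc(-c3cc(=O)c4ccccc4o3)cc2c1OC(C)C`: > 10000 nM
Compound 3 `O=C(/C=C/c1csc2ccccc12)c1cc(F)ccc1O`: 7400 nM

All three compounds were tested in a functional assay on KB cells (Homo sapiens) for antiproliferative activity, read by sulforhodamine B assay, with a stated time of 72 h; on this read-out lower numbers stand for stronger inhibition and higher numbers for weaker inhibition. Compound 1 gives only a limit (> 10000 nM). Compound 2 also gives only a limit (> 10000 nM). Going by the values given here, compound 3 therefore stands alone as the only compound with a number (7400 nM).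

Compound 4 `Cc1ccc(O)c(C(=O)/C=C/c2csc3ccccc23)c1` has not yet been measured. It carries methyl in place of fluoro on an aromatic carbon, at a place meta to a large group and para to a hydroxy group. Among the compounds with values here, no measured pair here shows what such an exchange does, so no step beyond the usual scatter is expected in this assay, and no direction is favoured. Within the data shown here, this expectation rests on the single number for compound 3 (7400 nM). The estimate amounts to an expected 1.1-fold lower number from compound 3 to compound 4 (0.06 log units; within the scatter). For compound 4 the estimated value is 6500 nM, with an expected range from 2500 nM to 15000 nM.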

Compound 4, half-maximal inhibitory concentration: 4900 nM
Compound 4: the middle estimate sits 1.3-fold (0.12 log units) above what was measured; the range from low to high includes it.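

In this assay, methyl in place of fluoro on an aromatic carbon, meta to a large group and para to a hydroxy group, gives a 1.5-fold lower number from compound 3 to compound 4 (0.18 log units; within the scatter). This first pair at this position shows that the exchange leaves the read-out within the scatter, so neither group can be preferred here. Compound 1 and compound 2 each gave only a limit and showed nothing about this position: the limit of > 10000 nM in this assay, at which 2 of the 4 values shown sit.

Fluoro and methyl each count one heavy atom and no hydrogen-bond donors or acceptors, so whether an amine, a carboxylic acid or a longer chain at this place would move the number beyond the scatter remains open. On these data alone, a single pair is all that speaks to this exchange, and whether it would act alike on another core also stays open.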